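The source may hold more compounds than are shown below. What is called first, only, known or untested is meant among the compounds shown, and "the series" means these compounds.

Measured compounds:

compound 1, `CCc1ccc(-c2nc3c(c(C)nn3-c3ccccc3)c(-c3ccccc3O)c2C#N)cc1`: in an ADME assay on BJ cells (Homo sapiens) for cytotoxicity, with a stated time of 72 h (a lower number here means that less compound is needed, a higher number that more compound is needed for the effect), compound 1 gives > 20000 nM, which is a limit of the assay.
compound 2, `CCc1ccc(-c2nc3c(c(C)nn3-c3ccccc3)c(-c3ccccc3[N+](=O)[O-])c2C#N)cc1`: in this assay compound 2 gives > 20000 nM, again a limit.
compound 3, `CCc1ccc(-c2nc3c(c(C)nn3-c3ccccc3)c(-c3ccccc3I)c2C#N)cc1`: in this assay compound 3 gives > 20000 nM, also a limit.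

Compound 1 therefore stands only at a limit in this assay, and the two further values are limits as well; all three sit at the same point (the limit of > 20000 nM in this assay, at which 3 of the 3 values shown sit). The steps a step that the two limits leave unreadable from compound 1 to compound 2, a step that the two limits leave unreadable from compound 1 to compound 3 and a step that the two limits leave unreadable from compound 2 to compound 3 are unreadable in size, so nothing can be said of how hydroxy, nitro or iodo on that aromatic carbon move the read-out beyond the fact that none brought a value into the measurable range.

The unmeasured compound 4, `CCc1ccc(-c2nc3c(c(C)nn3-c3ccccc3)c(-c3ccccc3F)c2C#N)cc1`, differs from compound 1 by fluoro in place of hydroxy on an aromatic carbon. For the measured compounds named here, no measured step bears readably on this change. Given that compound 1 stands at a limit, the expectation for a step that the limit leaves unreadable from compound 1 to compound 4 is no readable step, with compound 4 most likely also reported as a limit. Compound 4 is estimated at 30000 nM, range 15000 nM to 80000 nM.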

Compound 4, half-maximal effective concentration: > 20000 nM
Compound 4: a limit, no number; the forecaster's own chance of this, stated with the estimate: 85%; the middle value is on the limit's open side.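

In this assay compound 4 gives > 20000 nM, which is a limit, so its steps from compound 1, compound 2 and compound 3 cannot be read. The compounds shown leave open how hydroxy, nitro, iodo and fluoro on that aromatic carbon compare in size of effect.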